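Thioether side-chain variation on the shared core: compounds 1 to 3

The source may report more compounds than this note shows. Statements on the series, on what has been measured and on what is new or still open speak of the compounds shown alone.

Measured so far:
Compound 1 `O=c1c2ccccc2[se]n1-c1nc(SCc2ccccc2)n[nH]1`; in a functional assay on HeLa cells (Homo sapiens) for antiproliferative activity, read by CCK-8 assay, with a stated time of 48 h (a lower number here means a stronger inhibitor, a higher number a weaker inhibitor), compound 1 gives > 50000 nM, which is a limit of the assay.
Compound 2 `O=c1c2ccccc2[se]n1-c1nc(SCc2ccc(F)cc2)n[nH]1`; in this assay compound 2 gives > 50000 nM, again a limit.

Compound 2 therefore stands at the limit in this assay: no number is known for it, only that it lies beyond the range measured. Going by the values given here, both values shown sit at the same limit (the limit of > 50000 nM in this assay, at which 2 of the 2 values shown sit), so the single step between measured compounds, a step that the two limits leave unreadable from compound 1 to compound 2, cannot be sized; fluoro in place of hydrogen on an aromatic carbon leaves both compounds beyond the limit. Compound 3 `CCCSc1n[nH]c(-n2[se]c3ccccc3c2=O)n1` differs from compound 2 by ethyl in place of 4-fluorophenyl on a saturated chain carbon bound to a sulfur; cut one bond further out, the change reads 4-fluorobenzyl to propyl. Among the compounds with values here, the only measured step bears on it weakly: it is unreadable, both its ends being limits, so no direction beyond the scatter can be drawn from it. Given a step that the two limits leave unreadable from compound 1 to compound 2 as the sole guide, compound 3 is expected to stay at the limit as well, the step that the limit leaves unreadable from compound 2 to compound 3 being an estimate only. The estimate for compound 3 in this assay is 80000 nM, with a range from 20000 nM to 300000 nM, and a limit is the most likely report.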

Compound 3, half-maximal inhibitory concentration: 30400 nM
The estimate for compound 3 lay 2.6-fold (0.42 log units) above the measured number; low and high end bracket the measured number.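

In this assay compound 3 gives 30400 nM, the first actual number for the shared core among the compounds shown, so the side chain on the sulfur can bring this series inside the measured range. Ethyl in place of 4-fluorophenyl on a saturated chain carbon bound to a sulfur gives an at least 1.6-fold lower number from compound 2 to compound 3 (0.21 log units; that floor lies within the scatter), and ethyl in place of phenyl at the same place gives an at least 1.6-fold lower number from compound 1 to compound 3 (0.21 log units; that floor lies within the scatter), so the two steps agree in direction, but neither is shown to exceed the scatter. Their true sizes stay unknown because the starting value of each step is a limit and not a number: the limit of > 50000 nM in this assay, at which 2 of the 3 values shown sit.

With propyl as the only chain without a ring, the compounds shown cannot tell whether a methyl group, a butyl chain or a longer chain would lower the number further or return it to the limit. Also open, from the compounds shown here alone, is how a propyl chain carrying an amine or a carboxylic acid would read in this assay, and whether any side chain on this core can give a step clearly beyond the scatter.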